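From compound 1 to compound 4: an added aminomethyl

This account rests on a few compounds, and the source may have more. Where it says the series, first, only, none or still open, it means among the compounds named here.

Measured so far in a physicochemical assay for solubility; a higher number here means a more soluble compound, a lower number a less soluble compound:
- Compound 1 `O=C(Nc1ccccc1)c1cc2cc([N+](=O)[O-])ccc2s1`: 10 ug/mL
- Compound 2 `COC(=O)c1ccc(NC(=O)c2cc3cc([N+](=O)[O-])ccc3s2)cc1`: 10 ug/mL
- Compound 3 `COC(=O)c1cccc(NC(=O)c2cccc3ccccc23)c1`: < 5 ug/mL (a limit of the assay, not a number)

Going by the values given here, compound 1 stands level with compound 2, its only measured neighbour differing in one place. The value of compound 3 is a limit, so it gives no exact distance from compound 1.

Compound 4 `NCc1ccccc1NC(=O)c1cc2cc([N+](=O)[O-])ccc2s1` has not yet been measured. It differs from compound 1 by a single change, aminomethyl in place of hydrogen on an aromatic carbon, ortho to a large group.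

Among the compounds with values here, one measured step bears on this change. In no change at the digits printed from compound 1 to compound 2 (within the scatter), methoxycarbonyl takes the place of hydrogen on an aromatic carbon, and the result stays within the scatter. That step involves a different group, so it is only a loose guide. With compound 2 at 10 ug/mL, a large jump in this assay is not expected, and a small upward move is the cautious expectation, which may not clear the scatter. The expected step is a 1.4-fold higher number from compound 1 to compound 4 (0.15 log units; within the scatter). For compound 4 the estimate is 14 ug/mL, with an expected range of 5 ug/mL to 45 ug/mL.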

Compound 4, solubility: 1000 ug/mL
For compound 4 the middle estimate is 71-fold (1.85 log units) below the measured one, outside the stated range (above it).
By their numbers in this assay, from the lowest: compounds 1 and 2 (each within the scatter of the next); then compound 4. At a limit, below all of these: compound 3.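

In this assay, aminomethyl in place of hydrogen on an aromatic carbon, ortho to a large group, gives a 100-fold higher number from compound 1 to compound 4 (2.00 log units; beyond the scatter), so this single small change can move the read-out by a wide margin on the core of compound 1. Going by these compounds alone, the only earlier step on this same six-membered aromatic ring, no change at the digits printed from compound 1 to compound 2 (within the scatter), with methoxycarbonyl entering in place of hydrogen, could have suggested that changes to this ring leave the number where it is, and the new step shows that this does not hold for every group. The data shown give no measured property of the aminomethyl group or of compound 4 that would account for the size of this step.

As far as these compounds go, it remains open whether the nitrogen of the aminomethyl group accounts for the step or whether the added carbon contributes too, a question that a hydroxymethyl or a plain methyl in the same place would help to separate. From the compounds shown here alone, it is also open whether a longer chain ending in an amine, or a carboxylic acid, would give a step of similar size, and whether aminomethyl would do so elsewhere on this ring.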